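From Isopropyl to 2-Chlorophenyl: An Expected Limit

This account rests on a few compounds, and the source may have more. Where it says the series, first, only, none or still open, it means among the compounds named here.

Compound 2 `CC(C)CNC(=S)N1CC(C)C(c2ccccc2)=N1` is one of three measured analogs that share a core. In an ADME assay on KB cells (Homo sapiens) for cytotoxicity, read by MTT assay, with a stated time of 44 h (on this read-out higher numbers stand for weaker inhibition and lower numbers for stronger inhibition), compound 2 gives > 100000 nM, which is a limit of the assay rather than a number. Compound 1 `CCCCNC(=S)N1CC(C)C(c2ccccc2)=N1` likewise gives > 100000 nM in this assay, also a limit. Compound 3 `CC1CN(C(=S)NC2CCCC2)N=C1c1ccccc1` gives > 100000 nM in this assay, again a limit. The steps among these three, a step that the two limits leave unreadable from compound 1 to compound 2, a step that the two limits leave unreadable from compound 1 to compound 3 and a step that the two limits leave unreadable from compound 2 to compound 3, cannot be read in size because of the limit of > 100000 nM in this assay, at which 3 of the 3 values shown sit. Compound 4 `CC1CN(C(=S)NCc2ccccc2Cl)N=C1c1ccccc1` differs from compound 2 by 2-chlorophenyl in place of isopropyl on a saturated chain carbon bound to an amide-type nitrogen. Within the data shown here, none of the measured steps exchanges a saturated group for an aromatic one, so they bear on the new step only in showing that three different substituents at this position all left the value at the limit. Compound 4 is therefore expected to sit at the limit as well, with an estimated step that the limit leaves unreadable from compound 2 to compound 4. The estimate for compound 4 is 150000 nM, ranging from 30000 nM to 500000 nM.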

Compound 4, half-maximal inhibitory concentration: > 100000 nM
Compound 4: no number, only a limit; the forecaster's own chance of this, stated with the estimate: 75%; the middle value is on the limit's open side.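

Compound 4 gives > 100000 nM in this assay, which is a limit and not a number. No step from compound 1 or compound 2 to compound 4 can be read in size, because the values share one limit: the limit of > 100000 nM in this assay, at which 4 of the 4 values shown sit.

The compounds shown leave open how these four substituents rank against one another in this assay.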